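The source may report more compounds than this note shows. Statements on the series, on what has been measured and on what is new or still open speak of the compounds shown alone.

Working notes on the series. Compound 1 `COc1cc(Cl)cc(-c2nn(-c3cccc(NC(=O)Nc4ccc(Cl)c(C(F)(F)F)c4)c3)cc2-c2ccncc2)c1` gives -51% in a functional assay on K562 cells (Homo sapiens) for inhibition, read by sulforhodamine B assay, with a stated time of 48 h, tested at 100 uM; on this read-out higher numbers stand for a weaker effect at the one concentration tested and lower numbers for a stronger effect. Compound 2 `COc1cc(Cl)cc(-c2nn(-c3cccc(NC(=O)Nc4cccc(C(F)(F)F)c4)c3)cc2-c2ccncc2)c1`, which carries hydrogen in place of chloro on an aromatic carbon, gives -22%; the step is a number 29 percentage points higher from compound 1 to compound 2 (beyond the scatter). Among the measured compounds shown here, compound 2 therefore stands at the highest of the two numbers so far, with compound 1 as its only neighbour.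

Compound 3 `COc1cc(Cl)cc(-c2nn(-c3cccc(NC(=O)c4cccc(C(F)(F)F)c4)c3)cc2-c2ccncc2)c1` is not yet measured. It differs from compound 2 by 3-(trifluoromethyl)phenyl in place of (3-(trifluoromethyl)phenyl)amino on a carbonyl carbon. For the measured compounds named here, the only measured step, from compound 1 to compound 2, concerns a change on an aromatic carbon far from the carbonyl carbon and does not bear on this change; no measured pair shows a carbonyl carbon losing an attached nitrogen. The expectation for compound 3 is therefore built on compound 2 alone and allows a step of a number 7 percentage points higher from compound 2 to compound 3 (within the scatter) with a wide range. Compound 3 is expected to give about -15%, between -50% and 20%.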

Compound 3, a percentage reported as activity, at one concentration (the size of the read-out at that concentration, not a potency): 32%
Compound 3: the middle estimate sits 47 percentage points below what was measured; measured number outside the range, above it.
By their numbers in this assay, from the lowest: compound 1; then compound 2; then compound 3.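

At the carbonyl carbon, 3-(trifluoromethyl)phenyl in place of (3-(trifluoromethyl)phenyl)amino removes one nitrogen and one hydrogen-bond donor, and in this assay this gives a number 54 percentage points higher from compound 2 to compound 3 (beyond the scatter). This large step shows that the read-out depends strongly on what is attached at this carbonyl carbon, more than the earlier modest chloro step suggested, and the comparison with the chloro-bearing amino group gives a number 83 percentage points higher from compound 1 to compound 3 (beyond the scatter). No measurement on hand explains why this change has such an effect.

The compounds shown leave open whether the step follows the loss of the nitrogen itself or of its hydrogen, which a methylamino group carrying the same aryl ring on this carbonyl carbon could separate. They also leave open whether a methylene group in place of that nitrogen would behave like compound 3 or like compound 2.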